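The compounds below may be only part of what the source reports. "The series", "measured", "known", "first", "only" and "open" are said of these compounds alone.

Compound 2 `CC1CCN(C2CCN(S(=O)(=O)c3ccccc3-c3ccc(C(F)(F)F)cc3)CC2)CC1` is one of three biphenyl sulfonamides sharing the same core. In a functional assay on DLD-1 cells (Homo sapiens) for antiproliferative activity, read by CellTiter-Glo, with a stated time of 72 h (a higher number here means a weaker inhibitor, a lower number a stronger inhibitor), compound 2 gives 122 nM. This is the second highest of the three numbers: compound 1 `Cc1ccc(-c2ccccc2S(=O)(=O)N2CCC(N3CCC(C)CC3)CC2)cc1` gives 366 nM, and compound 3 `CC1CCN(C2CCN(S(=O)(=O)c3cccc(-c4ccc(F)cc4)c3)CC2)CC1` gives 12 nM, the lowest of the three. Among the measured compounds shown here, the one measured step at the same place is a 3.0-fold lower number from compound 1 to compound 2 (0.48 log units; beyond the scatter), a modest shift. Compound 4 `CC1CCN(C2CCN(S(=O)(=O)c3ccccc3-c3ccc(Cl)cc3)CC2)CC1` carries the change (chloro in place of trifluoromethyl on an aromatic carbon). For the measured compounds named here, no measured step shows a chloro at this place, and the only step that bears on it, from compound 1 to compound 2, is small, so the swap to chloro is expected to move this assay by at most a small step, most likely within the scatter. Compound 4 is expected to give 180 nM in this assay, with a range from 70 nM to 450 nM, which would mean a step of a 1.5-fold higher number from compound 2 to compound 4 (0.17 log units; within the scatter) that is not expected to go beyond the scatter.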

Compound 4, half-maximal inhibitory concentration: 202 nM
Estimate against measurement, compound 4: 1.1-fold (0.05 log units) below, within the range that was stated.
By their numbers in this assay, from the lowest: compound 3; then compounds 2, 4 and 1 (each within the scatter of the next, the first and the last beyond it).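

At this place, this assay shows a 1.7-fold higher number from compound 2 to compound 4 (0.22 log units; within the scatter) and a 1.8-fold lower number from compound 1 to compound 4 (0.26 log units; within the scatter) on the change to chloro, so chloro cannot be told apart from either trifluoromethyl or methyl. Only methyl and trifluoromethyl are separated, by a 3.0-fold lower number from compound 1 to compound 2 (0.48 log units; beyond the scatter) beyond the scatter, and the three groups therefore give no full ranking at this place. No measurement at hand accounts for these small steps. The compounds leave open how this place responds to a group of another kind, such as a methoxy, an amine or a carboxylic acid, on the same ring as the chloro of compound 4. They also leave open whether chloro, methyl and trifluoromethyl would read alike on the core of compound 3.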